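This account rests on a few compounds, and the source may have more. Where it says the series, first, only, none or still open, it means among the compounds named here.

Measured so far in an assay on isolated protein for displacement of a labelled ligand from Apoptosis regulator Bcl-2 (Homo sapiens), with a stated time of 15 min; a higher number here means a weaker inhibitor, a lower number a stronger inhibitor:

compound 1 `CC1(C)CCC(CN2CCN(c3ccc(C(=O)NS(=O)(=O)c4ccc(NCC5CCOCC5)c([N+](=O)[O-])c4)c(Oc4cnc5[nH]ccc5c4)c3)CC2)=C(c2ccc(C(F)(F)F)cc2)C1` — 1.5 nM
compound 2 `CC1(C)CCC(CN2CCN(c3ccc(C(=O)NS(=O)(=O)c4ccc(NC5CCOC5)c([N+](=O)[O-])c4)c(Oc4cnc5[nH]ccc5c4)c3)CC2)=C(c2ccc(C(F)(F)F)cc2)C1` — 1.9 nM
compound 3 `CC1(C)CCC(CN2CCN(c3ccc(C(=O)NS(=O)(=O)c4ccc(OCC5CCOCC5)c([N+](=O)[O-])c4)c(Oc4cnc5[nH]ccc5c4)c3)CC2)=C(c2ccc(C(F)(F)F)cc2)C1` — 1 nM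

Compound 3 gives the smallest number of the three in this assay, but neither gap separates it from its neighbours: a 1.5-fold lower number from compound 1 to compound 3 (0.18 log units; within the scatter) and a 1.9-fold lower number from compound 2 to compound 3 (0.28 log units; within the scatter) both sit inside the scatter, so the three compounds are to be read as equivalent on these numbers.

Compound 4 `CC1(C)CCC(CN2CCN(c3ccc(C(=O)NS(=O)(=O)c4ccc(OCC5CCSCC5)c([N+](=O)[O-])c4)c(Oc4cnc5[nH]ccc5c4)c3)CC2)=C(c2ccc(C(F)(F)F)cc2)C1` is not yet measured. It differs from compound 3 in one place: thian-4-yl in place of oxan-4-yl on a saturated chain carbon bound to an oxygen on an aromatic ring. For the measured compounds named here, none of the measured steps touches the ring heteroatom. a 1.3-fold higher number from compound 1 to compound 2 (0.10 log units; within the scatter) swaps the ring size and point of attachment on the nitrogen-linked side chain; a 1.5-fold lower number from compound 1 to compound 3 (0.18 log units; within the scatter) and a 1.9-fold lower number from compound 2 to compound 3 (0.28 log units; within the scatter) exchange the nitrogen link for an oxygen link. All three steps remain within the scatter, so the side chain at this position has so far tolerated every variation tried without a step beyond the noise. Going by the values given here, the oxygen-to-sulfur exchange in compound 4 is untested here, and no measured compound speaks to it directly; the expectation rests only on the flatness of the series so far.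

Compound 4 is therefore expected to land close to compound 3, with a 1.2-fold higher number from compound 3 to compound 4 (0.08 log units; within the scatter) as the expected step and no movement beyond the scatter; the estimate for compound 4 in this assay is 1.2 nM, with a range from 0.5 nM to 3 nM.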

Compound 4, half-maximal inhibitory concentration: 1.65 nM
Beside the measured number, compound 4's estimate is 1.4-fold (0.14 log units) below it, within the range that was stated.
By their numbers in this assay, from the lowest: compounds 3, 1, 4 and 2 (each within the scatter of the next).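

In this assay, for the compounds shown here, the ring heteroatom of the side chain is varied for the first time in these compounds: thian-4-yl in place of oxan-4-yl on a saturated chain carbon bound to an oxygen on an aromatic ring gives a 1.7-fold higher number from compound 3 to compound 4 (0.22 log units; within the scatter), so this exchange, like the earlier changes of ring size and linking atom, produces no step beyond the scatter. The larger replacements of the whole side chain agree with this, with a 1.2-fold lower number from compound 2 to compound 4 (0.06 log units; within the scatter) and a 1.1-fold higher number from compound 1 to compound 4 (0.04 log units; within the scatter), so all four compounds read as equivalent and the position has tolerated every variation shown so far. No supporting measurement bears on the result, so the flatness stands as an observation without an explanation.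

Still open, as far as these compounds go, is whether any group at this position can move the number beyond the scatter, for example a piperidin-4-yl ring carrying a basic amine, a carboxylic acid on the chain, or a longer chain between the ring and the linking oxygen. Also open, from the compounds shown here alone, is whether thian-4-yl behaves the same way when the side chain is linked through nitrogen rather than oxygen.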